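The compounds below may be only part of what the source reports. "The series", "measured", "known", "first", "only" and "open" are said of these compounds alone.

In a functional assay on HCT-15 cells (Homo sapiens) for cytotoxicity, read by colorimetric assay and MTT assay (on this read-out lower numbers stand for stronger inhibition and higher numbers for weaker inhibition), three compounds have been measured so far: compound 1 `COc1cccc2cc(-c3ccccc3)c(O)nc12` (10000 nM), compound 2 `COc1cc(OC)c2cc(-c3ccc(OCc4ccccc4)cc3)c(O)nc2c1` (10000 nM) and compound 3 `CCN(CC)C(=O)Cn1c(=O)c(-c2ccc(OC)cc2)cc2c(OC)cc(OC)cc21` (10000 nM). Compound 3 therefore stands level with the other two at the digits shown. Compound 4 `COc1ccc(-c2cc3c(OC)cc(OC)cc3n(CCC(=O)OCc3ccccc3)c2=O)cc1` has (benzyloxycarbonyl)methyl in place of diethylcarbamoyl on a saturated chain carbon bound to an aromatic nitrogen. Among the measured compounds shown here, no measured pair differs in only one place, so the data do not show how much such a swap can matter. Compound 2 also carries a benzyl group and still gives 10000 nM in this read-out, so no step beyond the scatter is expected in this assay here. The expected change is small (a 1.3-fold lower number from compound 3 to compound 4 (0.10 log units; within the scatter)). The estimated value for compound 4 is 8000 nM (expected range 3000 nM to 20000 nM).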

Compound 4, half-maximal inhibitory concentration: 10000 nM
The estimate for compound 4 lay 1.3-fold (0.10 log units) below the measured number, and the stated range covers the measured number.
By their numbers in this assay, from the lowest: compounds 1, 2, 3 and 4 (each within the scatter of the next).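

Among the compounds shown here, the swap of diethylcarbamoyl for (benzyloxycarbonyl)methyl on a saturated chain carbon bound to an aromatic nitrogen gives no change at the digits printed from compound 3 to compound 4 (within the scatter) in this assay and is the first comparison here of two compounds that differ in one place. At this position, then, the larger group with its six-membered aromatic ring of carbon only reads the same as diethylcarbamoyl. No supporting data explain this result. From the compounds shown here alone, all four compounds print the same number, so it remains open whether any group at this position can shift the read-out. A primary amine or a carboxylic acid at this place might or might not read differently.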